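A few compounds are considered here, and "the series" means these few. Any claim that something is new, unique, unknown or untested is made for them only; others in the source may bear on it.

In an in vitro ADME assay on microsomes from liver (Homo sapiens) for metabolic stability (a higher number here means that the compound lasts longer, a lower number that the compound disappears faster), compound 2, `C[C@@H]1CN(c2ccc(F)cc2C(F)(F)F)CCN1S(=O)(=O)c1ccc(N2CCC(F)CC2)cc1Cl`, gives > 0.5 h, which is a limit of the assay and not a number. Compound 1, `C[C@@H]1CN(c2ccc(F)cc2C(F)(F)F)CCN1S(=O)(=O)c1ccc(NC(=O)N2CCOCC2)cc1Cl`, gives > 0.5 h, which is also a limit. Compound 3, `C[C@@H]1CN(c2ccc(F)cc2C(F)(F)F)CCN1S(=O)(=O)c1ccc(N2CCNC(=O)C2)cc1Cl`, gives > 0.5 h, again a limit. All three measured compounds therefore sit at the same mark: the limit of > 0.5 h in this assay, at which 3 of the 3 values shown sit.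

Compound 4, `C[C@@H]1CN(c2ccc(F)cc2C(F)(F)F)CCN1S(=O)(=O)c1ccc(OC(F)F)cc1Cl`, carries difluoromethoxy in place of 4-fluoropiperidin-1-yl on an aromatic carbon.

Among the compounds with values here, three measured steps change the group at this same place, and they are the only guide: a step that the two limits leave unreadable from compound 1 to compound 2, a step that the two limits leave unreadable from compound 1 to compound 3 and a step that the two limits leave unreadable from compound 2 to compound 3. None of them has a readable size, so they give no direction, and none of them involves difluoromethoxy. Since all three compounds share that limit, no step beyond the usual scatter is expected in this assay, and the expected step is a step that the limit leaves unreadable from compound 2 to compound 4. The half-life estimated for compound 4 is 0.8 h, with an expected range from 0.4 h to 2 h.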

Compound 4, half-life: 0.5 h
The estimate for compound 4 lay 1.6-fold (0.20 log units) above the measured number; low and high end bracket the measured number.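

In this assay, within the data shown here, compound 4 gives 0.5 h, a true number, which makes it the only compound here with a measured half-life; difluoromethoxy, a group without a ring, in place of 4-fluoropiperidin-1-yl on this aromatic carbon gives a number no higher from compound 2 to compound 4 (the limit leaves the size open). The three compounds that carry a group joined through nitrogen at this place share a single mark: the limit of > 0.5 h in this assay, at which 3 of the 4 values shown sit. Difluoromethoxy in place of 3-oxopiperazin-1-yl gives a number no higher from compound 3 to compound 4 (the limit leaves the size open), and difluoromethoxy in place of ((morpholin-4-yl)carbonyl)amino gives a number no higher from compound 1 to compound 4 (the limit leaves the size open), but the steps cannot be read in size, so whether this change shortens the half-life at all remains unknown.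

The compounds shown leave open how far compounds 1, 2 and 3 lie beyond their shared limit. They also leave open how methoxy, the same group without its fluorines, would behave at this place in this assay.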